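The source may hold more compounds than are shown below. What is called first, only, known or untested is meant among the compounds shown, and "the series" means these compounds.

Two compounds have so far been taken through an ADME assay on HEK293 cells (Homo sapiens) for cytotoxicity, read by resazurin assay, with a stated time of 48 h; a lower number here means that less compound is tolerated, a higher number that more compound is tolerated. Compound 1 `O=S(=O)(Nc1ccc2oc(-c3ccccc3)nc2c1)c1cccc(C(F)(F)F)c1` gives > 100000 nM, which is a limit of the assay rather than a number. Compound 2 `CS(=O)(=O)Nc1ccc(-c2nc3ccccc3o2)cc1` gives > 100000 nM, likewise a limit. Going by the values given here, both values sit at the limit of > 100000 nM in this assay, at which 2 of the 2 values shown sit, so compound 2 stands exactly where the only other measured compound stands, with no number of its own. Compound 3 `COc1ccc(S(=O)(=O)Nc2ccc(-c3nc4ccccc4o3)cc2)cc1` is the next compound to be measured; it differs from compound 2 by 4-methoxyphenyl in place of methyl on a sulfonyl sulfur. Among the compounds with values here, no step between measured compounds is available to gauge this kind of change, and the two measured values show no difference between them, both being limits. In this assay the step from compound 2 to compound 3 is expected to be a number no higher from compound 2 to compound 3 (the limit leaves the size open), that is, nothing beyond the usual scatter. Compound 3 is therefore expected to give 100000 nM, within a range from 30000 nM to 300000 nM.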

Compound 3, half-maximal cytotoxic concentration: > 100000 nM
Compound 3: only a limit was reported; the forecaster's own chance of this, stated with the estimate: 80%; the middle value lies on the limit itself.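

Going by these compounds alone, compound 3, like compound 2, gives only a limit in this assay, so no step between compound 2 and compound 3 can be read: the limit of > 100000 nM in this assay, at which 3 of the 3 values shown sit. The compounds shown leave open what concentration any of them would need to reach the half-maximal cytotoxic level in this assay, and whether 4-methoxyphenyl in place of methyl changes that concentration at all.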